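Amide series: amino in place of methyl at the ring carbon

The source may report more compounds than this note shows. Statements on the series, on what has been measured and on what is new or still open speak of the compounds shown alone.

The shared core is set by compound 1 `O=C(Nc1ccccn1)c1cc2n(n1)CCCC2`, which in a functional assay on HEK293 cells for negative allosteric modulation of metabotropic glutamate receptor 5 (Rattus norvegicus), read by FLIPR and calcium flux, with a stated time of 170 s (a higher number here means a weaker inhibitor, a lower number a stronger inhibitor), gives 364 nM. Compound 2 `N#Cc1cccnc1NC(=O)c1cc2n(n1)CCCC2` carries a nitrile on the ring and in this assay is recorded as "not active" (no number reported). Compound 3 `Cc1cccnc1NC(=O)c1cc2n(n1)CCCC2` carries a methyl at the same carbon and in this assay is likewise recorded as "not active" (no number reported); it therefore stands without a number, alongside one further entry of the same kind. Compound 4 `Nc1cccnc1NC(=O)c1cc2n(n1)CCCC2` differs from compound 3 by amino in place of methyl on an aromatic carbon. Among the compounds with values here, with no measured step for comparison, and the two substituted analogues each without activity, no gain beyond the scatter is expected; a further entry without a number is the more likely outcome. Compound 4 is estimated at 6000 nM, range 1000 nM to 40000 nM.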

Compound 4, half-maximal inhibitory concentration: > 10000 nM
Compound 4 ended at the assay's limit; the forecaster's own chance of this, stated with the estimate: 60%; middle value at least 1.6-fold (0.22 log units) from the limit.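

Amino in place of hydrogen on this aromatic carbon gives the first readable step at this position in this assay, an at least 27-fold higher number from compound 1 to compound 4 (1.43 log units; beyond the scatter). The value of compound 4 is a limit, not a number: the limit of > 10000 nM in this assay, at which 1 of the 4 values shown sits. With compound 2 and compound 3, this makes nitrile, methyl and amino at this carbon all without measurable activity, and none of these compounds goes against that; steps among the three cannot be read.

From the compounds shown here alone, whether a fluorine or a methoxy at this carbon would keep activity stays open. So does the effect of an amino on the other ring carbons.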